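This account rests on a few compounds, and the source may have more. Where it says the series, first, only, none or still open, it means among the compounds named here.

Working notes on the series. The measured set is compound 1 `Fc1ccc(-c2nn3ccc(NC4CCCC4)cc3c2-c2ccnc(NC3CCCC3)n2)cc1`, compound 2 `Fc1ccc(-c2nn3c(Cl)cc(NC4CCCC4)cc3c2-c2ccnc(NC3CCCC3)n2)cc1` and compound 3 `CC(C)Sc1cc(NC2CCCC2)cc2c(-c3ccnc(NC4CCCC4)n3)c(-c3ccc(F)cc3)nn12`. In an ADME assay on Vero cells (Chlorocebus sabaeus) for cytotoxicity (a lower number here means that less compound is tolerated, a higher number that more compound is tolerated), compound 1 gives 18000 nM. Compound 2 reaches only a limit of the assay, > 40000 nM. Compound 3 likewise stops at a limit of the assay, > 40000 nM; that is all that is known of where it stands. Two of the three values sit at this limit (the limit of > 40000 nM in this assay, at which 2 of the 3 values shown sit). The steps of an at least 2.2-fold higher number from compound 1 to compound 2 (0.34 log units; beyond the scatter) and an at least 2.2-fold higher number from compound 1 to compound 3 (0.34 log units; beyond the scatter) both run toward that limit, while a step that the two limits leave unreadable from compound 2 to compound 3 remains unreadable. Compound 4 `COCCOc1cc(NC2CCCC2)cc2c(-c3ccnc(NC4CCCC4)n3)c(-c3ccc(F)cc3)nn12` carries 2-methoxyethoxy in place of isopropylsulfanyl on an aromatic carbon. For the measured compounds named here, no measured step covers this swap; the nearest are an at least 2.2-fold higher number from compound 1 to compound 3 (0.34 log units; beyond the scatter) and the unreadable a step that the two limits leave unreadable from compound 2 to compound 3. Compound 4 is therefore expected to stay near the limit, with a number no higher from compound 3 to compound 4 (the limit leaves the size open) estimated as no step beyond the scatter, at about 40000 nM (range 15000 nM to 80000 nM).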

Compound 4, half-maximal cytotoxic concentration: 32500 nM
Estimate against measurement, compound 4: 1.2-fold (0.09 log units) above, and the stated range covers the measured number.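

In this assay, for the compounds shown here, 2-methoxyethoxy on the aromatic carbon next to the ring nitrogen gives the only exact number among the substituted compounds, and the step to it, a 1.8-fold higher number from compound 1 to compound 4 (0.26 log units; within the scatter), does not separate it from the hydrogen of compound 1. Against the other two substituents only floors can be read: an at least 1.2-fold lower number from compound 3 to compound 4 (0.09 log units; that floor lies within the scatter) and an at least 1.2-fold lower number from compound 2 to compound 4 (0.09 log units; that floor lies within the scatter). Compound 2 and compound 3 stay at a limit of the assay: the limit of > 40000 nM in this assay, at which 2 of the 4 values shown sit.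

As far as these compounds go, how far compound 2 and compound 3 lie beyond that limit stays open. So does the outcome for an amine or a carboxylic acid at the end of a longer chain at this position.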